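This account rests on a few compounds, and the source may have more. Where it says the series, first, only, none or still open, it means among the compounds named here.

Measured in an ADME assay on L1210/0 cells (Mus musculus) for cytotoxicity, with a stated time of 48 h; on this read-out lower numbers stand for stronger inhibition and higher numbers for weaker inhibition:
- compound 1 `C=Cc1cn([C@H]2C[C@H](O)[C@@H](CO)O2)c(=O)[nH]c1=O`: 14200 nM
- compound 2 `O=C(CI)NCc1cn([C@H]2C[C@H](O)[C@@H](CO)O2)c(=O)[nH]c1=O`: 107000 nM
- compound 3 `N#Cc1cn([C@H]2C[C@H](O)[C@@H](CO)O2)c(=O)[nH]c1=O`: > 200000 nM (a limit)

As far as these compounds go, compound 3 sits at the limit of > 200000 nM in this assay, at which 1 of the 3 values shown sits: it gives only a limit and no number, so its true value is unknown.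

Compound 4 `O=c1[nH]c(=O)n([C@H]2C[C@H](O)[C@@H](CO)O2)cc1C#CCCCO` keeps the shared core but carries 5-hydroxypent-1-yn-1-yl in place of cyano on an aromatic carbon.

Going by the values given here, no measured step makes this exact swap, but all three change the same carbon. The cyano group of compound 3 accounts for an at least 14-fold higher number from compound 1 to compound 3 (1.14 log units; beyond the scatter), which shows that this carbon can move the number a long way. Exchanging vinyl for the longer chain of compound 2 gives a 7.5-fold higher number from compound 1 to compound 2 (0.88 log units; beyond the scatter), and an at least 1.8-fold higher number from compound 2 to compound 3 (0.27 log units; that floor lies within the scatter) adds little more. A long chain at this carbon has therefore been measured only once, in compound 2 with 107000 nM.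

On that single example, a modest step towards lower numbers is expected in this assay, though compound 4 could also stay at the limit. The expected change is an at least 2.8-fold lower number from compound 3 to compound 4 (0.45 log units; beyond the scatter). For compound 4 the estimate is 70000 nM, with an expected range from 15000 nM to 250000 nM.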

Compound 4, half-maximal inhibitory concentration: > 200000 nM
Compound 4 gave a limit, no number (the forecaster's own chance of this, stated with the estimate: 30%); middle value at least 2.8-fold (0.45 log units) away from the limit.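

In this assay compound 4 gives > 200000 nM, which is a limit and not a number, so a second, quite different group on this aromatic carbon ends at the same limit as the nitrile of compound 3: the limit of > 200000 nM in this assay, at which 2 of the 4 values shown sit.

Swapping out the vinyl group gives an at least 14-fold higher number from compound 1 to compound 4 (1.14 log units; beyond the scatter), so of the groups shown, vinyl alone keeps a clearly lower number than this chain. Measured against the other long chain, the step is an at least 1.8-fold higher number from compound 2 to compound 4 (0.27 log units; that floor lies within the scatter), so 5-hydroxypent-1-yn-1-yl cannot yet be ranked below (((iodomethyl)carbonyl)amino)methyl, and the step from the nitrile to this chain cannot be read, as both ends of it are limits.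

The compounds shown leave open whether a smaller group on this carbon, such as ethynyl or ethyl, would give a number as low as vinyl does. They also leave open whether the hydroxyl at the end of the chain plays any part, which the same chain ending in an amine or in a plain methyl group could test.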